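Lengthening the Chain Branch in a Bombesin Receptor Agonist Series

The source may hold more compounds than are shown below. What is called first, only, known or untested is meant among the compounds shown, and "the series" means these compounds.

Compound 1 `CCCCc1cnc(C(C)Cc2ccc(-c3ccccc3C(=O)O)cc2)[nH]1` stands at the high end of the three numbers in hand: in an in vitro functional assay on cells for agonist activity at Bombesin receptor subtype-3 (Homo sapiens), read by luminescence and calcium flux (a higher number here means that more compound is needed for the effect, a lower number that less compound is needed), compound 1 gives 2760 nM. Compound 3 `O=C(O)c1ccccc1-c1ccc(CCc2ncc(Cc3ccc(Cl)cc3)[nH]2)cc1` gives 2290 nM in this assay, and the two lie within the scatter of each other. Compound 2 `Cc1ccccc1Cc1cnc(CCc2ccc(-c3ccccc3C(=O)O)cc2)[nH]1` gives 127 nM in this assay, far lower than compound 1. For the measured compounds named here, the one step between measured neighbours, an 18-fold higher number from compound 2 to compound 3 (1.26 log units; beyond the scatter), concerns the group on a saturated chain carbon bound to an aromatic carbon and does not touch the site changed here.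

Compound 4 `CCCCc1cnc(C(CC)Cc2ccc(-c3ccccc3C(=O)O)cc2)[nH]1` differs from compound 1 by methyl in place of hydrogen on a saturated chain carbon, two bonds along the chain from an aromatic carbon; the same difference, cut one bond further out, reads methyl to ethyl. Going by the values given here, none of the measured steps vary this branch, so the series offers no precedent for its effect, and compound 1 already stands at the high end of the numbers. A step of no size beyond the scatter is therefore expected, a 1.1-fold lower number from compound 1 to compound 4 (0.04 log units; within the scatter). Compound 4 is expected to give 2500 nM in this assay, within a range of 900 nM to 7000 nM.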

Compound 4, half-maximal effective concentration: 2720 nM
Compound 4: the middle estimate sits 1.1-fold (0.04 log units) below what was measured; low and high end bracket the measured number.
By their numbers in this assay, from the lowest: compound 2; then compounds 3, 4 and 1 (each within the scatter of the next).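

In this assay, the step from methyl to ethyl at this branch leaves the number in place, with a 1.0-fold lower number from compound 1 to compound 4 (0.01 log units; within the scatter) for methyl in place of hydrogen on a saturated chain carbon, two bonds along the chain from an aromatic carbon. For the compounds shown here, this is the first reading of a change at this branch, and it shows that, with the rest of compound 1 held fixed, the added carbon neither lowers nor raises the number beyond the scatter. No measurement is available here that bears on why this is so.

The compounds shown leave open whether a longer chain such as propyl, or an amine or a hydroxyl group, on this carbon would shift the number. They also leave open whether the same change would read alike on a compound carrying the 2-methylphenyl group of compound 2.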